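Trifluoromethyl for Methyl on the Aryl Substituent

A few compounds are considered here, and "the series" means these few. Any claim that something is new, unique, unknown or untested is made for them only; others in the source may bear on it.

Three compounds built on one shared core differ only in the group carried on an aromatic carbon of one six-membered ring. Compound 1 `COc1cc(/C=C/C(=O)OCCSc2nc(-c3ccc(S(C)(=O)=O)cc3)n(-c3ccc(Br)cc3)n2)ccc1OC(C)=O` gives 12400 nM in a functional assay on B16-F10 cells (Mus musculus) for antiproliferative activity, read by MTT assay, with a stated time of 72 h; on this read-out lower numbers stand for stronger inhibition and higher numbers for weaker inhibition. Compound 2 `COc1cc(/C=C/C(=O)OCCSc2nc(-c3ccc(S(C)(=O)=O)cc3)n(-c3ccc(F)cc3)n2)ccc1OC(C)=O` gives 11200 nM in this assay, and compound 3 `COc1cc(/C=C/C(=O)OCCSc2nc(-c3ccc(S(C)(=O)=O)cc3)n(-c3ccc(C)cc3)n2)ccc1OC(C)=O` gives 15300 nM in this assay. Compound 3 gives the highest of the three numbers, yet every step among them lies within the scatter: a 1.1-fold lower number from compound 1 to compound 2 (0.04 log units; within the scatter); a 1.2-fold higher number from compound 1 to compound 3 (0.09 log units; within the scatter); a 1.4-fold higher number from compound 2 to compound 3 (0.14 log units; within the scatter).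

Compound 4 `COc1cc(/C=C/C(=O)OCCSc2nc(-c3ccc(S(C)(=O)=O)cc3)n(-c3ccc(C(F)(F)F)cc3)n2)ccc1OC(C)=O` has not yet been measured. It differs from compound 3 by trifluoromethyl in place of methyl on an aromatic carbon. Within the data shown here, no measured step makes exactly this exchange, but the three steps that swap the group at this same place, bromo to fluoro, bromo to methyl and fluoro to methyl, all stayed within the scatter, so the exchange to trifluoromethyl is expected to give a step in this assay of no clear direction, a 1.1-fold lower number from compound 3 to compound 4 (0.04 log units; within the scatter). Compound 4 is therefore estimated at 14000 nM, within a range from 6000 nM to 35000 nM.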

Compound 4, half-maximal inhibitory concentration: 10500 nM
The estimate for compound 4 lay 1.3-fold (0.12 log units) above the measured number; the measured number falls inside the stated range.
By their numbers in this assay, from the lowest: compounds 4, 2, 1 and 3 (each within the scatter of the next).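

Trifluoromethyl at this aromatic carbon behaves like the three groups before it in this assay, with a 1.5-fold lower number from compound 3 to compound 4 (0.16 log units; within the scatter), a 1.1-fold lower number from compound 2 to compound 4 (0.03 log units; within the scatter) and a 1.2-fold lower number from compound 1 to compound 4 (0.07 log units; within the scatter). The earlier compounds shown here carried only methyl and single halogen atoms here, and adding trifluoromethyl extends the flat picture to a group of four heavy atoms, so all four compounds remain indistinguishable in this read-out. Nothing available here explains why this position shows so little response.

From the compounds shown here alone, whether a different kind of group at this place, such as an amine, a carboxylic acid or a longer alkyl chain, would shift the number beyond the scatter remains open. Also open is how much changes elsewhere on the shared core would matter, since only this one position varies among the compounds shown.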